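Adding a Second Chlorine Where Three Compounds Hit a Ceiling

The source may hold more compounds than are shown below. What is called first, only, known or untested is meant among the compounds shown, and "the series" means these compounds.

Compound 3 `O=C(/C=C\c1ccccc1Cl)N1N=C(c2ccncc2)OC1c1c[nH]c2ccccc12` carries a 2-chlorophenyl group on its double-bonded chain. In an ADME assay on A549 cells (Homo sapiens) for cytotoxicity, read by MTT assay, with a stated time of 48 h (a lower number here means a stronger inhibitor of growth, a higher number a weaker inhibitor of growth), compound 3 gives > 30 ug/mL, which is a limit of the assay rather than a measured number. Compound 1 `O=C(/C=C\c1ccccc1)N1N=C(c2ccncc2)OC1c1c[nH]c2ccccc12`, the unsubstituted parent, gives > 30 ug/mL in this assay, again a limit. Compound 2 `Cc1ccc(/C=C\C(=O)N2N=C(c3ccncc3)OC2c2c[nH]c3ccccc23)cc1`, with a methyl on the ring, gives > 30 ug/mL in this assay, once more a limit. All three therefore stand at the limit of > 30 ug/mL in this assay, at which 3 of the 3 values shown sit, and no ordering among them can be read. The steps a step that the two limits leave unreadable from compound 1 to compound 2, a step that the two limits leave unreadable from compound 1 to compound 3 and a step that the two limits leave unreadable from compound 2 to compound 3 remain unreadable in size, because the limit of > 30 ug/mL in this assay, at which 3 of the 3 values shown sit, hides both ends of each.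

Compound 4 `O=C(/C=C\c1cccc(Cl)c1Cl)N1N=C(c2ccncc2)OC1c1c[nH]c2ccccc12` differs from compound 3 by chloro in place of hydrogen on an aromatic carbon. Since every comparable change so far has left the result at the ceiling, the expected step that the limit leaves unreadable from compound 3 to compound 4 is none beyond the scatter. Compound 4 is therefore estimated at 45 ug/mL in this assay, most likely again reported only as a limit, within a range of 20 ug/mL to 150 ug/mL.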

Compound 4, concentration for 50% growth inhibition: > 30 ug/mL
Compound 4 gave a limit, no number (the forecaster's own chance of this, stated with the estimate: 80%); the middle value does not contradict the limit.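

In this assay compound 4 gives > 30 ug/mL, again a limit. Its steps from compound 1, compound 2 and compound 3 therefore cannot be read: the limit of > 30 ug/mL in this assay, at which 4 of the 4 values shown sit.

The compounds shown leave open how strongly any of them inhibits growth, and whether any of these substituents changes that.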